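Fluorophenyl for methoxyphenyl on compound 3

A few compounds are considered here, and "the series" means these few. Any claim that something is new, unique, unknown or untested is made for them only; others in the source may bear on it.

Of the compounds shown here, three have numbers so far. In a functional assay, with a stated time of 10 min (on this read-out lower numbers stand for stronger inhibition and higher numbers for weaker inhibition), compound 1 `COc1ccc(-c2nc(SC)n(C)c(=O)c2C#N)cc1` gives 48 ug/mL. For the measured compounds named here, compound 2 `COc1ccc(-c2nc(NN)n(C)c(=O)c2C#N)cc1` gives 32 ug/mL in this assay, and the only single-point step measured, a 1.5-fold lower number from compound 1 to compound 2 (0.18 log units; within the scatter), stays within the scatter. Compound 3 `CCOC(=O)c1cnn(-c2nc(-c3ccc(OC)cc3)c(C#N)c(=O)n2C)c1N` gives 74 ug/mL in this assay, the highest number of the three; the gap to compound 1 lies within the scatter, the gap to compound 2 beyond it.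

Compound 4 `CCOC(=O)c1cnn(-c2nc(-c3ccccc3F)c(C#N)c(=O)n2C)c1N` differs from compound 3 at one place: 2-fluorophenyl in place of 4-methoxyphenyl on an aromatic carbon. Going by the values given here, no measured step touches this aryl group, since the one step available varies a different substituent, so there is no direct precedent for the size or direction of this change. Across the three compounds the numbers span a narrow band. In this assay compound 4 is therefore expected to stay near compound 3, with a 1.1-fold higher number from compound 3 to compound 4 (0.03 log units; within the scatter) as the expected step, and no shift beyond the scatter. The estimate for compound 4 is 80 ug/mL, with a range from 35 ug/mL to 180 ug/mL.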

Compound 4, half-maximal inhibitory concentration: 86 ug/mL
Beside the measured number, compound 4's estimate is 1.1-fold (0.03 log units) below it, within the range that was stated.
By their numbers in this assay, from the lowest: compounds 2, 1, 3 and 4 (each within the scatter of the next, the first and the last beyond it).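

In this assay the aryl group on the core gets its first measured step: 2-fluorophenyl in place of 4-methoxyphenyl gives a 1.2-fold higher number from compound 3 to compound 4 (0.07 log units; within the scatter). This one exchange alters the substituent and where it sits on the aromatic ring, and also takes away the one hydrogen-bond acceptor of the leaving group, yet the read-out does not separate the two compounds, so on this pair the position accepts either aryl group. No measurement of any property of these two groups bears on this result.

Both groups are substituted phenyl rings, and the effects of swapping the substituent and of moving it remain unseparated in this single step. Going by these compounds, whether an unsubstituted phenyl, or a phenyl carrying an amine or a carboxylic acid, would shift the number at this position stays open.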